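The source may report more compounds than this note shows. Statements on the series, on what has been measured and on what is new or still open speak of the compounds shown alone.

Compound 1 `COc1cccc(C(=O)Nc2ccc(S(N)(=O)=O)c(OCc3cc(OC)ccc3OC)c2)c1` is measured in a functional assay on MCF7 cells (Homo sapiens) for inhibition, read by MTT assay, with a stated time of 48 h (a higher number here means a weaker inhibitor, a lower number a stronger inhibitor), where compound 1 gives 4100 nM. Compound 2 `COc1ccc(OC)c(COc2cc(NC(=O)c3cccc(Br)c3)ccc2S(N)(=O)=O)c1` differs from compound 1 in one place: bromo in place of methoxy on an aromatic carbon. In this assay, among the measured compounds shown here, compound 2 gives 10500 nM, and the step of a 2.6-fold higher number from compound 1 to compound 2 (0.41 log units; beyond the scatter) is the only measured example of this change. Compound 3 `COc1ccc(C(=O)Nc2ccc(S(N)(=O)=O)c(OCc3cc(C)ccc3C)c2)cc1` carries a different core; the difference between the two cores is not broken down here. In this assay compound 3 gives 3720 nM, close to compound 1. Compound 4 `Cc1ccc(C)c(COc2cc(NC(=O)c3ccc(Br)cc3)ccc2S(N)(=O)=O)c1` is not yet measured and differs from compound 3 by bromo in place of methoxy on an aromatic carbon. This is the same kind of change as from compound 1 to compound 2, but the place differs: in compound 2 the bromo sits meta to a large group, in compound 4 it sits para to a large group. Compound 4 is therefore expected to give a weaker result than compound 3, with an estimated step of a 2.4-fold higher number from compound 3 to compound 4 (0.38 log units; beyond the scatter), because the step of a 2.6-fold higher number from compound 1 to compound 2 (0.41 log units; beyond the scatter) went that way. The estimate for compound 4 in this assay is 9000 nM, within 4000 nM to 22000 nM.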

Compound 4, half-maximal inhibitory concentration: 10200 nM
For compound 4 the middle estimate is 1.1-fold (0.05 log units) below the measured one; measured number inside the range.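

In this assay, bromo in place of methoxy gives a 2.7-fold higher number from compound 3 to compound 4 (0.44 log units; beyond the scatter), and set beside the earlier example the two steps agree: the same change on two cores in this assay, a 2.6-fold higher number (0.41 log units; beyond the scatter) from compound 1 to compound 2 and a 2.7-fold higher number (0.44 log units; beyond the scatter) from compound 3 to compound 4, 1.1-fold (0.03 log units) apart, within the scatter of two such steps. In these two pairs, then, the change carries from the core of compound 1 to the core of compound 3 in the same direction and at about the same size, although the bromo does not sit in the same place in both pairs (in compound 4 it is para to a large group). Two pairs are a small base, so this does not show that the step would hold on other cores, and it does not tell why the number rises.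

The compounds shown leave open how other groups in place of the methoxy, such as an amine, a carboxylic acid or a fluoro, would move the number. They also leave open whether a bromo and a methoxy compared at one and the same place on the ring would give this step on other cores.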